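A few compounds are considered here, and "the series" means these few. Any claim that something is new, unique, unknown or untested is made for them only; others in the source may bear on it.

Measured so far in a physicochemical assay for lipophilicity; a lower number here means a more polar compound, a higher number a more lipophilic compound:

compound 1, `CC[n+]1ccn(CCN(C)C)c1/C=N/O`: compound 1 gives -2.71
compound 2, `CCC(Cn1cc[n+](C)c1/C=N/O)N(C)C`: compound 2 gives -2.57
compound 3, `CCN(CCn1cc[n+](C)c1/C=N/O)S(C)(=O)=O`: compound 3 gives -2.72

All three numbers in this assay sit close together; compound 3 lies within the scatter of compound 1 and also within the scatter of compound 2, so the three values cannot be told apart. Compound 3 differs from the other two in carrying a methylsulfonyl group on its side chain rather than a dimethylamino group.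

Compound 4, `CCN(CCn1cc[n+](C)c1/C=N/O)S(=O)(=O)C(F)(F)F`, is the next member: the change from compound 3 is trifluoromethyl in place of methyl on a sulfonyl sulfur, in words trifluoromethyl in place of methyl on a sulfonyl sulfur, or methylsulfonyl to (trifluoromethyl)sulfonyl. For the measured compounds named here, no pair among the measured compounds shows this change, so no measured step can be borrowed. The expectation is a step upward in this assay, of a size just beyond the scatter rather than a large shift. Compound 4 is expected to give about -2.3, with a range from -2.7 to -1.9. The estimated step of a number 0.42 log units higher from compound 3 to compound 4 (beyond the scatter) is expected to be upward and modest.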

Compound 4, distribution coefficient: -1.03
The estimate for compound 4 lay 1.27 log units below the measured number, and the stated range ends below it.
By their numbers in this assay, from the lowest: compounds 3, 1 and 2 (each within the scatter of the next); then compound 4.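

In this assay, for the compounds shown here, trifluoromethyl in place of methyl on a sulfonyl sulfur gives a number 1.69 log units higher from compound 3 to compound 4 (beyond the scatter) and is the only step read between compounds that differ in one place. The position on the sulfonyl sulfur is therefore not silent: exchanging this one group, with no net charge and no hydrogen-bond donor or acceptor counted on either side, moves the number well beyond the scatter. No measurement at hand accounts for the size of this step.

This single pair cannot show whether ethyl, phenyl or a difluoromethyl group on the same sulfonyl sulfur would give a step of similar size. It also leaves open whether the step would persist with a longer chain in place of the ethyl group on the sulfonamide nitrogen.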